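Aryl exchange on the shared core: expectation for compound 4

This account rests on a few compounds, and the source may have more. Where it says the series, first, only, none or still open, it means among the compounds named here.

In a functional assay on CHO cells for agonist activity at Free fatty acid receptor 1 (Homo sapiens), read by FLIPR and calcium flux, tested at 100 nM (on this read-out higher numbers stand for a stronger effect at the one concentration tested and lower numbers for a weaker effect), compound 3 `Cc1nc(-c2ccsc2)sc1COc1ccc2c(c1)OCC2CC(=O)O` gives 56.5%. Compound 1 `Cc1nc(-c2ccccc2)sc1COc1ccc2c(c1)OCC2CC(=O)O` gives 54.8%, and the step of a number 1.7 percentage points higher from compound 1 to compound 3 (within the scatter) lies within the scatter, so compound 3 and compound 1 sit together on this read-out. Compound 2 `Cc1cc(COc2ccc3c(c2)OCC3CC(=O)O)nn1-c1ccccc1` gives 0.98%, far below both. Compound 4 `Cc1nc(-c2cc3ccccc3o2)sc1COc1ccc2c(c1)OCC2CC(=O)O` differs from compound 3 by 1-benzofuran-2-yl in place of thiophen-3-yl on an aromatic carbon. Within the data shown here, the only measured step that bears on this place is a number 1.7 percentage points higher from compound 1 to compound 3 (within the scatter), an exchange of one aromatic group for another that left the number unchanged within the scatter. On that basis no step beyond the scatter is expected for a number 1.5 percentage points lower from compound 3 to compound 4 (within the scatter). The entering group is however larger than anything tested there, so the range is kept wide. Compound 4 is therefore estimated at 55%, between 30% and 78%.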

Compound 4, a percentage reported as activity, at one concentration (the size of the read-out at that concentration, not a potency): 14.8%
For compound 4 the middle estimate is 40.2 percentage points above the measured one, outside the stated range (below it).
By their numbers in this assay, from the lowest: compound 2; then compound 4; then compounds 1 and 3 (each within the scatter of the next).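

Not every aromatic group is tolerated alike on this aromatic carbon next to the ring nitrogen and the ring sulfur. In this assay the exchange for 1-benzofuran-2-yl gives a number 41.7 percentage points lower from compound 3 to compound 4 (beyond the scatter) and a number 40 percentage points lower from compound 1 to compound 4 (beyond the scatter) in this series, whereas the exchange between phenyl and thiophen-3-yl stayed within the scatter. Of the three groups, only 1-benzofuran-2-yl has a five-membered aromatic ring joined to a six-membered one, but this single compound cannot establish a trend.

No available evidence explains the drop. On these data alone, it remains open whether the loss follows the added ring or the oxygen in place of sulfur, and a naphthalen-2-yl or a furan-2-yl group at this position would separate the two.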